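Phenyl in Place of Ethyl: Expecting Compound 4

The compounds below may be only part of what the source reports. "The series", "measured", "known", "first", "only" and "open" are said of these compounds alone.

Measured compounds in a functional assay on the whole organism (blood, strain albino) with Mus musculus as the target, with stated times of 6 days and 4 h, at a dose of 0.4 mmol/kg by the oral route; a lower number here means less inhibition, a higher number more inhibition at the dose given (going by the name of the read-out):
compound 1, `Cc1cc(C(=O)O)nn1-c1ccc(S(=O)(=O)NC(=S)NCc2ccccc2)cc1`, gives < 2%.
compound 2, `Cc1cc(C(=O)O)nn1-c1ccc(S(=O)(=O)NC(=S)NC2CCCCC2)cc1`, gives 1%.
compound 3, `CCNC(=S)NS(=O)(=O)c1ccc(-n2nc(C(=O)O)cc2C)cc1`, gives -2%.

The three share one core and differ only in the group on the amide-type nitrogen whose other neighbour is the thiocarbonyl carbon. The value of compound 1 is a limit of this assay and not a number (the limit of < 2% in this assay, at which 1 of the 3 values shown sits). Compound 2 and compound 3 are the two compounds with actual numbers, and they sit within the usual scatter of each other: a number 3 percentage points lower from compound 2 to compound 3 (within the scatter). The other two steps, a step that the limit leaves unreadable from compound 1 to compound 2 and a step that the limit leaves unreadable from compound 1 to compound 3, have no readable size because of the limit of < 2% in this assay, at which 1 of the 3 values shown sits.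

Compound 4, `Cc1cc(C(=O)O)nn1-c1ccc(S(=O)(=O)NC(=S)Nc2ccccc2)cc1`, differs from compound 3 in one place: phenyl in place of ethyl on an amide-type nitrogen. Among the compounds with values here, the only readable step, from cyclohexyl to ethyl, did not move the read-out beyond the scatter, and the steps involving benzyl cannot be sized; nothing measured here points to a change of any size or direction when ethyl becomes phenyl. Compound 4 is therefore expected to give 1%, within a range from -8% to 10%. The estimated step of a number 3 percentage points higher from compound 3 to compound 4 (within the scatter) is expected to stay within the scatter, and a value reported only as a limit remains possible.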

Compound 4, a percentage reported as inhibition, in the whole organism at one dose (the size of the read-out at that dose, not a potency): 0%
Compound 4: the middle estimate sits 1 percentage points above what was measured, within the range that was stated.
By their numbers in this assay, from the lowest: compounds 3, 4 and 2 (each within the scatter of the next).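

In this assay, an aromatic ring set on the amide-type nitrogen gives a number 2 percentage points higher from compound 3 to compound 4 (within the scatter), and phenyl in place of cyclohexyl gives a number 1 percentage points lower from compound 2 to compound 4 (within the scatter). Until now this nitrogen had carried only an open chain, a saturated ring and a benzyl group, so compound 4 adds the case of a six-membered aromatic ring bound to it, and among compound 2, compound 3 and compound 4 neither the ring type nor the change from ethyl to the larger phenyl produces a step beyond the scatter. The value of compound 1 is a limit, and the step from it to compound 4 cannot be read: the limit of < 2% in this assay, at which 1 of the 4 values shown sits.

As far as these compounds go, what remains open is whether any group on this nitrogen can move the read-out beyond the scatter, for example a longer chain, a phenyl ring carrying an amine or a methoxy group, or a chain ending in a carboxylic acid. The compounds shown also keep the thiocarbonyl and the carboxylic acid of the shared core unchanged, so they say nothing about a carbonyl in place of that thiocarbonyl or an ester in place of that acid.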